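The source may hold more compounds than are shown below. What is called first, only, known or untested is meant among the compounds shown, and "the series" means these compounds.

Compound 1 `Cc1ccc(OCC(=O)N(Cc2cccs2)c2ncccn2)cc1` is tested in an assay on HEK293 cells for agonist activity at transient receptor potential cation channel subfamily M member 8 (Homo sapiens), read by fluorescence and calcium flux, with a stated time of 15 min (on this read-out lower numbers stand for an effect already at smaller amounts and higher numbers for an effect only at larger amounts of compound), and gives 3700 nM. Of the two values at hand this is the higher: compound 2 `CCN(Cc1cccs1)C(=O)CCc1ccc(C)cc1` gives 93 nM in this assay, and the two numbers lie well apart. Compound 3 `Cc1ccc(OCC(=O)N(Cc2cccs2)c2ccccn2)cc1` is the untested partner of compound 1, differing in one place (pyridin-2-yl in place of pyrimidin-2-yl on an amide-type nitrogen). Within the data shown here, no measured pair shows this exact change, so its effect is uncertain. For compound 3 the step in this assay a 1.9-fold lower number from compound 1 to compound 3 (0.27 log units; within the scatter) is expected to be small, leaning toward a lower number but possibly within the scatter. Compound 3 is therefore estimated at 2000 nM, with a range from 600 nM to 6000 nM.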

Compound 3, half-maximal effective concentration: 200 nM
Beside the measured number, compound 3's estimate is 10-fold (1.00 log units) above it; the measured number lies below the stated range.
By their numbers in this assay, from the lowest: compound 2; then compound 3; then compound 1.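

In this assay putting pyridin-2-yl in place of pyrimidin-2-yl on the amide-type nitrogen gives a 19-fold lower number from compound 1 to compound 3 (1.27 log units; beyond the scatter). So this position is sensitive: a large step comes from exchanging one ring nitrogen for carbon, while the six-membered aromatic ring and its heavy-atom count stay the same. Nothing measured here explains the size of this step. Still open, going by these compounds, is whether phenyl, with no ring nitrogen, would continue the trend. It is also unclear whether the same swap would have a similar effect on a different core.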